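Ester exchange and metabolic half-life in a small series

The source may report more compounds than this note shows. Statements on the series, on what has been measured and on what is new or still open speak of the compounds shown alone.

The measured compounds are compound 1 `Cc1cn([C@H]2C=C[C@@H](COP(=O)(O)OP(=O)(O)OCc3ccc(OC(=O)c4ccc(C(F)(F)F)cc4)cc3)O2)c(=O)[nH]c1=O`, which in an ADME assay on CCRF-CEM cells (Homo sapiens) for metabolic stability, read by HPLC, at 37 degrees C (a higher number here means that the compound lasts longer, a lower number that the compound disappears faster), gives 11.5 h; compound 2 `CCCCCCCCCCCC(=O)Oc1ccc(COP(=O)(O)OP(=O)(O)OC[C@@H]2C=C[C@H](n3cc(C)c(=O)[nH]c3=O)O2)cc1`, which in this assay gives 1.15 h; and compound 3 `Cc1cn([C@H]2C[C@H](N=[N+]=[N-])[C@@H](COP(=O)(O)OP(=O)(O)OCc3ccc(OC(=O)c4ccc(C(F)(F)F)cc4)cc3)O2)c(=O)[nH]c1=O`, which in this assay gives 3.83 h.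

Compound 1 and compound 2 differ in one place: undecyl in place of 4-(trifluoromethyl)phenyl on a carbonyl carbon. That change produced a 10-fold lower number from compound 1 to compound 2 (1.00 log units; beyond the scatter). Compound 3 stands between the two, with a higher number than compound 2 and a lower one than compound 1. The difference between the core of compound 1 and the core of compound 3 is not broken down here.

Compound 4 `CCCCCCCCCCCC(=O)Oc1ccc(COP(=O)(O)OP(=O)(O)OC[C@H]2O[C@@H](n3cc(C)c(=O)[nH]c3=O)C[C@@H]2N=[N+]=[N-])cc1` is not yet measured. It relates to compound 3 as compound 2 relates to compound 1: undecyl in place of 4-(trifluoromethyl)phenyl on a carbonyl carbon. Because the same change gave a 10-fold lower number from compound 1 to compound 2 (1.00 log units; beyond the scatter), a step of similar size is expected from compound 3, so that a 10-fold lower number from compound 3 to compound 4 (1.00 log units; beyond the scatter) is estimated in this assay. The expected half-life of compound 4 is therefore 0.38 h, likely between 0.18 h and 0.8 h.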

Compound 4, half-life: 1.05 h
Beside the measured number, compound 4's estimate is 2.8-fold (0.44 log units) below it, outside the stated range (above it).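

In this assay, putting undecyl in place of 4-(trifluoromethyl)phenyl on the carbonyl carbon again lowered the half-life, giving a 3.6-fold lower number from compound 3 to compound 4 (0.56 log units; beyond the scatter). The direction of the change therefore held on both cores in this series, but its size did not carry over unchanged: the same change on two cores in this assay, a 10-fold lower number (1.00 log units; beyond the scatter) from compound 1 to compound 2 and a 3.6-fold lower number (0.56 log units; beyond the scatter) from compound 3 to compound 4, 2.7-fold (0.44 log units) apart, beyond the scatter of two such steps These two pairs show that the size of the step depends on the core it is made on, but they do not show which feature of the cores is responsible, and two cores are too few to support a general rule for the series.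

The compounds shown leave open where a shorter or longer chain in place of undecyl, or a phenyl group carrying an amine or a carboxylic acid in place of trifluoromethyl, would fall on either core. On these data alone, it also remains open whether the change would follow the larger step, the smaller step or neither on a third core.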